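A few compounds are considered here, and "the series" means these few. Any claim that something is new, unique, unknown or untested is made for them only; others in the source may bear on it.

Compound 1 `O=C(c1ccn(-c2ccc3c(c2)B(O)OC3)c1)c1ccccc1Cl` in an ADME assay on L929 cells (Mus musculus) for cytotoxicity, read by resazurin assay, with a stated time of 72 h (on this read-out lower numbers stand for stronger inhibition and higher numbers for weaker inhibition), gives > 10 ug/mL, a limit of the assay rather than a number.
Compound 2 `O=C(c1ccc(Cl)cc1)c1ccn(-c2ccc3c(c2)B(O)OC3)c1` in this assay gives > 10 ug/mL, again only a limit.
Compound 3 `COc1ccc(C(=O)c2ccn(-c3ccc4c(c3)B(O)OC4)c2)cc1` in this assay gives > 10 ug/mL, also a limit.

Compound 3 therefore stands only at a limit, and nothing separates it from the other two: all three values sit at the same limit (the limit of > 10 ug/mL in this assay, at which 3 of the 3 values shown sit). Compound 4 `O=C(CCc1ccccc1)c1ccn(-c2ccc3c(c2)B(O)OC3)c1` differs from compound 3 by phenethyl in place of 4-methoxyphenyl on a carbonyl carbon. Two measured steps end at compound 3 and bear on this place: the step from compound 2 to compound 3, a step that the two limits leave unreadable from compound 2 to compound 3, and the step from compound 1 to compound 3, a step that the two limits leave unreadable from compound 1 to compound 3. The step from compound 1 to compound 2, a step that the two limits leave unreadable from compound 1 to compound 2, is just as unreadable. None of these yields a size, so no direction and no step beyond the scatter can be expected in this assay from them. The expected step is accordingly a step that the limit leaves unreadable from compound 3 to compound 4, without a resolved direction. Compound 4 is estimated at 15 ug/mL, within a range from 5 ug/mL to 50 ug/mL, and most likely it too will be reported only as a limit.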

Compound 4, half-maximal inhibitory concentration: > 10 ug/mL
Compound 4: only a limit was reported; the forecaster's own chance of this, stated with the estimate: 75%; the middle value lies beyond the limit too.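

In this assay compound 4 stands only at a limit, as do compound 1, compound 2 and compound 3, so no step among these compounds can be read: the limit of > 10 ug/mL in this assay, at which 4 of the 4 values shown sit.

The compounds shown leave open where any of their actual values lies, and whether changing the group on the carbonyl carbon alters this read-out at all.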